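This account rests on a few compounds, and the source may have more. Where it says the series, first, only, none or still open, it means among the compounds named here.

Two measured compounds set the frame. Compound 1 `CC(C)CCn1ccc(N2CCC(c3ccccc3)CC2)c(C#N)c1=O` gives 102 nM in a functional assay on CHO cells for positive allosteric modulation of metabotropic glutamate receptor 2 (Homo sapiens), with a stated time of 30 min (on this read-out higher numbers stand for an effect only at larger amounts of compound and lower numbers for an effect already at smaller amounts), and compound 2 `N#Cc1c(N2CCC(c3ccccc3F)CC2)ccn(CC2CC2)c1=O` gives 81 nM in this assay. These two numbers lie within the scatter of each other, so neither compound can be set apart from the other on this read-out.

Compound 3 `N#Cc1c(N2CCC(c3ccccc3Cl)CC2)ccn(CC2CC2)c1=O` has not yet been measured. It differs from compound 2 by a single change: chloro in place of fluoro on an aromatic carbon. Within the data shown here, no measured pair here shows what such a swap does, so the expectation rests only on compound 2 and the size of the change. The exchange of one halogen for another on an aromatic carbon is expected to shift this assay little, if at all, beyond the scatter, with the step from compound 2 to compound 3 estimated at a 1.2-fold lower number from compound 2 to compound 3 (0.06 log units; within the scatter). For compound 3 the expected value is therefore 70 nM, within a range from 25 nM to 200 nM.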

Compound 3, half-maximal effective concentration: 49 nM
The estimate for compound 3 lay 1.4-fold (0.15 log units) above the measured number; low and high end bracket the measured number.
By their numbers in this assay, from the lowest: compounds 3, 2 and 1 (each within the scatter of the next, the first and the last beyond it).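

Among these compounds, this is the first measured exchange at this position: with chloro in place of fluoro on an aromatic carbon ortho to a large group, this assay shows a 1.7-fold lower number from compound 2 to compound 3 (0.22 log units; within the scatter). The 2-chlorophenyl compound thus cannot be set apart from the 2-fluorophenyl compound, and this one position takes either halogen without a change that exceeds the scatter. Nothing measured here offers an explanation for this result.

Compound 1 carries no halogen on its phenyl ring but also differs from compound 2 and compound 3 in the chain on the ring nitrogen, so these compounds do not show what either halogen contributes by itself. As far as these compounds go, what a methyl group, a methoxy group or an amine would do at this same position remains open, as does the effect of a bromine atom.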